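From 2-methylphenyl to 3-chloro-4-methylphenyl

A few compounds are considered here, and "the series" means these few. Any claim that something is new, unique, unknown or untested is made for them only; others in the source may bear on it.

In a functional assay on KB cells (Homo sapiens) for antiproliferative activity, read by sulforhodamine B assay, with a stated time of 3 days (on this read-out lower numbers stand for an effect already at smaller amounts and higher numbers for an effect only at larger amounts of compound), compound 3 (`CCC1=C(O)c2c(oc(-c3ccccc3C)cc2=O)C(CC)(CC)C1=O`) gives 40.9 uM as the higher of the two actual numbers, with compound 1 (`CCC1=C(O)c2c(oc(-c3ccc(OC)cc3)cc2=O)C(CC)(CC)C1=O`) nearest at 17.7 uM on the lower side. Compound 2 (`CCC1=C(O)c2c(oc(-c3ccc(SC)cc3)cc2=O)C(CC)(CC)C1=O`) gives > 52.1 uM as a limit and not a number. Compound 4 (`CCC1=C(O)c2c(oc(-c3ccc(C)c(Cl)c3)cc2=O)C(CC)(CC)C1=O`) carries 3-chloro-4-methylphenyl in place of 2-methylphenyl (3-chloro-4-methylphenyl in place of 2-methylphenyl on an aromatic carbon) on the shared core. Among the measured compounds shown here, two measured steps bear on this: a 2.3-fold higher number from compound 1 to compound 3 (0.36 log units; beyond the scatter) and an at least 2.9-fold higher number from compound 1 to compound 2 (0.46 log units; beyond the scatter) are both modest. The new group resembles the 4-methoxyphenyl of compound 1, though compound 2 goes against leaning on that. The expected change is a 1.6-fold lower number from compound 3 to compound 4 (0.20 log units; within the scatter) and is estimated to be small, toward a lower number. In this assay compound 4 is expected at 26 uM with 11 uM to 55 uM as its likely range.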

Compound 4, concentration for half-maximal effect: 39 uM
Compound 4: middle estimate off by 1.5-fold (0.18 log units), on the low side; low and high end bracket the measured number.
By their numbers in this assay, from the lowest: compound 1; then compounds 4 and 3 (each within the scatter of the next). At a limit, above all of these: compound 2.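

In this assay, putting 3-chloro-4-methylphenyl in place of 2-methylphenyl gives a 1.0-fold lower number from compound 3 to compound 4 (0.02 log units; within the scatter). The 4-methoxyphenyl of compound 1 now stands apart from both of these groups, with a 2.2-fold higher number from compound 1 to compound 4 (0.34 log units; beyond the scatter) adding to the step already seen for compound 3. Compound 2 carries a limit and not a number: the limit of > 52.1 uM in this assay, at which 1 of the 4 values shown sits. The remaining step can therefore be given only as a floor, an at least 1.3-fold lower number from compound 2 to compound 4 (0.12 log units; that floor lies within the scatter).

Going by these compounds, whether an amine, a carboxylic acid or an unsubstituted phenyl at this position would fall with compound 1 or with compounds 3 and 4 stays open.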